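Pyrimidin-4-yl on the amide nitrogen: a cytotoxicity estimate

A few compounds are considered here, and "the series" means these few. Any claim that something is new, unique, unknown or untested is made for them only; others in the source may bear on it.

Measured so far in an ADME assay on LLC-MK2 cells (Macaca mulatta) for cytotoxicity, read by spectrophotometry and crystal violet staining, with a stated time of 4 days; on this read-out lower numbers stand for higher toxicity in this test and higher numbers for lower toxicity in this test:
compound 1, `CC(C)n1ncc2c(C(=O)Nc3ccncc3)cc(-c3cccs3)nc21`: 6300 nM
compound 2, `CC(C)n1ncc2c(C(=O)Nc3ccc(F)cn3)cc(-c3cccs3)nc21`: > 200000 nM

The two compounds share a core and differ only in the group on the amide-type nitrogen. Compound 1, with pyridin-4-yl there, gives a number in this assay. Compound 2, with 5-fluoropyridin-2-yl in that place, gives only a limit and not a number, namely (the limit of > 200000 nM in this assay, at which 1 of the 2 values shown sits). Among the measured compounds shown here, the one measured step between them, an at least 31-fold higher number from compound 1 to compound 2 (1.50 log units; beyond the scatter), is therefore large in the direction of lower toxicity but open-ended.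

Compound 3, `CC(C)n1ncc2c(C(=O)Nc3ccncn3)cc(-c3cccs3)nc21`, is not yet measured. It differs from compound 2 in one place: pyrimidin-4-yl in place of 5-fluoropyridin-2-yl on an amide-type nitrogen. For the measured compounds named here, the only step that bears on this change is an at least 31-fold higher number from compound 1 to compound 2 (1.50 log units; beyond the scatter), where pyridin-4-yl was exchanged for 5-fluoropyridin-2-yl. Going by the values given here, compound 3 carries a six-membered aromatic ring with two hetero atoms, neither the fluorine nor the pyridin-2-yl attachment of compound 2, and no step separates such a ring from either measured group.

On this footing compound 3 is expected to fall somewhere between compound 1 and the limit of compound 2, with the step of an at least 3.3-fold lower number from compound 2 to compound 3 (0.52 log units; beyond the scatter) estimated toward higher toxicity, though a second limit is a real possibility. The estimate for compound 3 in this assay is 60000 nM, with a range from 10000 nM to 200000 nM.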

Compound 3, half-maximal cytotoxic concentration: 50000 nM
Estimate against measurement, compound 3: 1.2-fold (0.08 log units) above; low and high end bracket the measured number.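

With compound 3, a six-membered aromatic ring with two hetero atoms on the amide-type nitrogen gives a real number in this assay, so this position now has two numbers to compare instead of one number and a limit. Against pyridin-4-yl, pyrimidin-4-yl brings a 7.9-fold higher number from compound 1 to compound 3 (0.90 log units; beyond the scatter), and against 5-fluoropyridin-2-yl it brings an at least 4.0-fold lower number from compound 2 to compound 3 (0.60 log units; beyond the scatter), which shows that the read-out at this position changes with the choice of ring and that lower toxicity in this test is not shared equally by the groups shown. Compound 2 gives a limit and not a number, so the second of these steps stays open-ended: the limit of > 200000 nM in this assay, at which 1 of the 3 values shown sits.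

The compounds shown do not separate the fluorine of compound 2 from its pyridin-2-yl attachment, so how much of the difference belongs to each stays open. Also open, as far as these compounds go, is how the read-out would respond to an unsubstituted pyridin-2-yl, or to a non-aromatic group such as a short alkyl chain or an amine-bearing chain, on the amide-type nitrogen.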